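Replacing Trifluoromethoxy with Bromo: an Expected Small Step

A few compounds are considered here, and "the series" means these few. Any claim that something is new, unique, unknown or untested is made for them only; others in the source may bear on it.

Measured compounds:
- compound 1 `COc1ccc(-c2cc(CN(c3nc4ccc(F)cc4s3)c3nc4ccc(OC)cc4s3)on2)cc1` gives 138000 nM
- compound 2 `FC(F)(F)Oc1ccc(-c2cc(CN(c3ncccn3)c3nc4ccccc4s3)on2)cc1` gives 13500 nM
- compound 3 `COc1cc(-c2cc(CN(c3ncccn3)c3nc4ccccc4s3)on2)cc(OC)c1OC` gives 26100 nM

In a functional assay on U-937 cells (Homo sapiens) for antiproliferative activity, read by MTT assay (a lower number here means a stronger inhibitor, a higher number a weaker inhibitor), compound 2 has the lowest number of the three, but compound 3 sits within the usual scatter of it, so the two cannot be ranked; only compound 1 lies clearly higher. Compound 4 `Brc1ccc(-c2cc(CN(c3ncccn3)c3nc4ccccc4s3)on2)cc1` differs from compound 2 by bromo in place of trifluoromethoxy on an aromatic carbon. Among the compounds with values here, no measured pair shows this change, so the expectation rests on compound 2 alone. The step is expected to stay within the scatter or only slightly beyond it, if anything toward a higher number. Compound 4 is therefore estimated at 18000 nM, with a range from 6000 nM to 55000 nM. This estimate corresponds to an expected 1.3-fold higher number from compound 2 to compound 4 (0.12 log units; within the scatter).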

Compound 4, half-maximal inhibitory concentration: 13600 nM
The estimate for compound 4 lay 1.3-fold (0.12 log units) above the measured number; the range from low to high includes it.
By their numbers in this assay, from the lowest: compounds 2, 4 and 3 (each within the scatter of the next); then compound 1.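

Within the data shown here, compound 2 and compound 4 form the first measured pair that differs only at this place on the aromatic ring. In this assay, bromo in place of trifluoromethoxy gives a 1.0-fold higher number from compound 2 to compound 4 (0.00 log units; within the scatter), so 4-bromophenyl and 4-(trifluoromethoxy)phenyl cannot be told apart, even though a group of 5 heavy atoms gives way to 1 heavy atom. Nothing available explains this match. On these data alone, whether an amine or a carboxylic acid at this place would give a similar number remains open, as does whether this match would hold on another core.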